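Pentyl replacing isopentylsulfanyl in a sulfonamide antagonist series

The compounds below may be only part of what the source reports. "The series", "measured", "known", "first", "only" and "open" are said of these compounds alone.

Measured so far:
compound 1 `CC(C(=O)NCc1ccc(C(F)(F)F)cc1OC1CCCC1)c1ccc(NS(C)(=O)=O)c(F)c1` gives 0.6 nM
compound 2 `CC(C)CCSc1cc(C(F)(F)F)ccc1CNC(=O)C(C)c1ccc(NS(C)(=O)=O)c(F)c1` gives 1.4 nM

Both numbers come from an assay on CHO cells for antagonist activity at transient receptor potential cation channel subfamily V member 1 (Homo sapiens), read by FLIPR; a higher number here means a weaker inhibitor, a lower number a stronger inhibitor. Among the compounds with values here, compound 2 stands at the higher of the two values; the one step measured so far, a 2.3-fold higher number from compound 1 to compound 2 (0.37 log units; beyond the scatter), is modest but beyond the scatter and separates it from compound 1.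

The next compound, compound 3 `CCCCCc1cc(C(F)(F)F)ccc1CNC(=O)C(C)c1ccc(NS(C)(=O)=O)c(F)c1`, differs from compound 2 by pentyl in place of isopentylsulfanyl on an aromatic carbon. Within the data shown here, no measured step removes the sulfur from this side chain, so the only guidance is that the exchange of a ring-bearing ether for a chain-bearing thioether, in the step from compound 1 to compound 2, cost only a little. A change of similar or smaller size is therefore expected here, with the direction uncertain, and the number may well stay within the scatter of compound 2. Compound 3 is estimated at 2.5 nM, with a range of 0.8 nM to 8 nM, meaning an expected step of a 1.8-fold higher number from compound 2 to compound 3 (0.25 log units; within the scatter).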

Compound 3, inhibition constant: 0.4 nM
Compound 3: the middle estimate sits 6.3-fold (0.80 log units) above what was measured; the whole stated range lies above it.
By their numbers in this assay, from the lowest: compounds 3 and 1 (each within the scatter of the next); then compound 2.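

In this assay, this position, ortho to a large group and meta to a trifluoromethyl group, accepts a chain joined directly through carbon: pentyl in place of isopentylsulfanyl gives a 3.5-fold lower number from compound 2 to compound 3 (0.54 log units; beyond the scatter). Pentyl in place of cyclopentyloxy gives a 1.5-fold lower number from compound 1 to compound 3 (0.18 log units; within the scatter), so among these compounds an oxygen or sulfur link to the ring is not needed to reach the level of the cyclopentyloxy ether. No available data explain the difference between the thioether and the pentyl chain.

The step from isopentylsulfanyl to pentyl removes the sulfur and the branch together, so their separate contributions remain unresolved; an isopentyl chain or a straight pentylsulfanyl chain would separate them. From the compounds shown here alone, how far this position tolerates a shorter propyl chain, a longer heptyl chain or a terminal amine also remains open.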